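This account rests on a few compounds, and the source may have more. Where it says the series, first, only, none or still open, it means among the compounds named here.

Working notes on the series. Three measured compounds share one core and differ only in the group on a saturated chain carbon bound to a sulfur: compound 1 `Cc1cc(N2CC[C@@H](C)[C@@H](N(C)c3ncnc4[nH]ccc34)C2)n2nc(SCc3ccc(Cl)cc3)nc2n1`, compound 2 `Cc1cc(N2CC[C@@H](C)[C@@H](N(C)c3ncnc4[nH]ccc34)C2)n2nc(SCc3nc4ccccc4[nH]3)nc2n1` and compound 3 `Cc1cc(N2CC[C@@H](C)[C@@H](N(C)c3ncnc4[nH]ccc34)C2)n2nc(SCc3csc4ccc(Cl)cc34)nc2n1`. In a functional assay on MGC-803 cells (Homo sapiens) for inhibition, read by MTT assay, with a stated time of 72 h (on this read-out higher numbers stand for weaker inhibition and lower numbers for stronger inhibition), compound 1 gives 16000 nM and compound 2 gives 21200 nM. Compound 3 returns only a limit in this assay, namely > 100000 nM. The measured steps are a 1.3-fold higher number from compound 1 to compound 2 (0.12 log units; within the scatter), an at least 6.2-fold higher number from compound 1 to compound 3 (0.79 log units; beyond the scatter) and an at least 4.7-fold higher number from compound 2 to compound 3 (0.67 log units; beyond the scatter); the latter two rest on (the limit of > 100000 nM in this assay, at which 1 of the 3 values shown sits). Compound 2 thus holds the higher of the two real numbers, with compound 1 nearest and within the scatter, while compound 3 sits beyond both at the limit.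

Compound 4 `Cc1cc(N2CC[C@@H](C)[C@@H](N(C)c3ncnc4[nH]ccc34)C2)n2nc(SCc3ccc(C(F)(F)F)cc3)nc2n1` is the next step from compound 2: 4-(trifluoromethyl)phenyl in place of 1H-benzimidazol-2-yl on a saturated chain carbon bound to a sulfur. For the measured compounds named here, no measured step involves a trifluoromethyl group, so the only guide is a 1.3-fold higher number from compound 1 to compound 2 (0.12 log units; within the scatter), in which replacing a ring-bearing aryl group by the benzimidazolyl group moved the number within the scatter only. Going back to a six-membered carbon ring is therefore expected to move the number little; the expected step is a 1.4-fold lower number from compound 2 to compound 4 (0.15 log units; within the scatter), a small decrease at most. Compound 4 is estimated at 15000 nM, between 6000 nM and 45000 nM.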

Compound 4, half-maximal inhibitory concentration: 2680 nM
Beside the measured number, compound 4's estimate is 5.6-fold (0.75 log units) above it; the whole stated range lies above it.
By their numbers in this assay, from the lowest: compound 4; then compounds 1 and 2 (each within the scatter of the next). At a limit, above all of these: compound 3.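

For the compounds shown here, compound 4 is the first compound whose number lies beyond the scatter of both earlier real numbers in this assay: a change on an aromatic carbon alone, trifluoromethyl in place of chloro, gives a 6.0-fold lower number from compound 1 to compound 4 (0.78 log units; beyond the scatter). The group on a saturated chain carbon bound to a sulfur therefore matters more than the earlier pair suggested, since 1H-benzimidazol-2-yl in place of 4-chlorophenyl gave only a 1.3-fold higher number from compound 1 to compound 2 (0.12 log units; within the scatter), whereas the exchange with 4-(trifluoromethyl)phenyl gives a 7.9-fold lower number from compound 2 to compound 4 (0.90 log units; beyond the scatter). Compound 3 stands at a limit of the assay, so an at least 37-fold lower number from compound 3 to compound 4 (1.57 log units; beyond the scatter) is a bound and not a measured size: the limit of > 100000 nM in this assay, at which 1 of the 4 values shown sits.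

Open remains whether the lower number belongs to trifluoromethyl in particular, or whether a methoxy group, a nitrile or a carboxylic acid on the same aromatic carbon would read alike. Also open, as far as these compounds go, is how a longer chain, such as 2-(4-(trifluoromethyl)phenyl)ethyl in place of 4-(trifluoromethyl)benzyl, would read in this assay.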